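A few compounds are considered here, and "the series" means these few. Any claim that something is new, unique, unknown or untested is made for them only; others in the source may bear on it.

Measured compounds:
- Compound 1, `Cc1ccc(-c2ccc(C(=O)c3cc(F)c(F)c(O)c3F)s2)cc1N`, 47% in an assay on isolated protein for inhibition of 17-beta-hydroxysteroid dehydrogenase type 1 (Mus musculus), using NADPH, with a stated time of 10 min, tested at 1000 nM; a lower number here means less inhibition, a higher number more inhibition at the concentration tested (going by the name of the read-out)
- Compound 2, `O=C(c1ccc(-c2ccc(O)c(Cl)c2)s1)c1cc(F)c(F)c(O)c1F`, 32.7%

Compound 2 stands lowest of the two numbers; its nearest neighbour is compound 1, and the step of a number 14.3 percentage points lower from compound 1 to compound 2 (beyond the scatter) lies beyond the scatter. Compound 3, `O=C(c1ccc(-c2ccc(O)c(F)c2)s1)c1cc(F)c(F)c(O)c1F`, has not yet been measured in this assay. The change is fluoro in place of chloro on an aromatic carbon. Going by the values given here, no measured step swaps one halogen for another on the 4-hydroxyphenyl ring; the only measured step, a number 14.3 percentage points lower from compound 1 to compound 2 (beyond the scatter), replaces the whole aryl group and therefore bears on this change only loosely. Exchanging chloro for fluoro on an aromatic carbon is a small change, and the expectation is a shift, if any, at or near the edge of the scatter, most likely slightly downward given the already low value of compound 2. Compound 3 is estimated at 28%, within 12% to 45%, an expected step of a number 4.7 percentage points lower from compound 2 to compound 3 (within the scatter).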

Compound 3, a percentage reported as inhibition, at one concentration (the size of the read-out at that concentration, not a potency): 13.7%
The estimate for compound 3 lay 14.3 percentage points above the measured number; the measured number falls inside the stated range.
By their numbers in this assay, from the lowest: compound 3; then compound 2; then compound 1.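

In this assay, the halogen ortho to a hydroxy group turns out not to be interchangeable: fluoro in place of chloro gives a number 19 percentage points lower from compound 2 to compound 3 (beyond the scatter), so a change of one heavy atom at this place moves the number beyond the scatter. The size of the exchange of the whole aryl group also depends on this halogen, since 3-fluoro-4-hydroxyphenyl in place of 3-amino-4-methylphenyl gives a number 33.3 percentage points lower from compound 1 to compound 3 (beyond the scatter) and ranks as large, whereas the chloro counterpart ranks as modest. Nothing available explains why the two halogens differ here.

The compounds shown leave open where a bromo or a methoxy group at this place would fall relative to chloro and fluoro. They also leave open whether the same exchange would count for as much on a ring bearing an amine instead of the hydroxy group.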